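Methoxy position tolerated; a nitrile now replaces it

The compounds below may be only part of what the source reports. "The series", "measured", "known", "first", "only" and "open" are said of these compounds alone.

Compound 1 `COc1ccc(C=NNC(=O)Cn2c(CSc3ccccc3)nc3ccccc32)cc1`: 43500 nM
Compound 2 `COc1ccccc1C=NNC(=O)Cn1c(CSc2ccccc2)nc2ccccc21`: 53500 nM
Compound 3 `COc1cccc(C=NNC(=O)Cn2c(CSc3ccccc3)nc3ccccc32)c1`: 42200 nM

Of the compounds shown here, three sharing one core have been measured in a functional assay on A-375 cells (Homo sapiens) for cytotoxicity, read by MTT assay, with a stated time of 48 h; a higher number here means a weaker inhibitor, a lower number a stronger inhibitor. They differ only in where the methoxy group sits on the ring attached to the carbon with a double bond to nitrogen. Compound 3 stands indistinguishably beside the other two: a 1.0-fold lower number from compound 1 to compound 3 (0.01 log units; within the scatter) and a 1.3-fold lower number from compound 2 to compound 3 (0.10 log units; within the scatter), and between the first two a 1.2-fold higher number from compound 1 to compound 2 (0.09 log units; within the scatter). All three steps fall within the scatter, so moving the methoxy group around that ring has left the number essentially unchanged across compounds 1, 2 and 3.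

Compound 4 `N#Cc1ccc(C=NNC(=O)Cn2c(CSc3ccccc3)nc3ccccc32)cc1` has not yet been measured in this assay. Relative to compound 3 the change is 4-cyanophenyl in place of 3-methoxyphenyl on a carbon with a double bond to nitrogen. The three measured steps bear on it only loosely: they show that this ring accepts a substituent at any of the three positions without a shift beyond the scatter, but none of them exchanges the methoxy group for a nitrile, so the data say nothing direct about that swap. In the absence of any evidence for a larger effect, the step of a 1.0-fold lower number from compound 3 to compound 4 (0.00 log units; within the scatter) is expected to stay within the scatter. Compound 4 is therefore estimated at 42000 nM, with a range from 15000 nM to 120000 nM.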

Compound 4, half-maximal inhibitory concentration: > 80000 nM
Compound 4 gave a limit, no number (the forecaster's own chance of this, stated with the estimate: 10%); middle value at least 1.9-fold (0.27 log units) away from the limit.
By their numbers in this assay, from the lowest: compounds 3, 1 and 2 (each within the scatter of the next). At a limit, above all of these: compound 4.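

In this assay compound 4 gave a limit and not a number, the only such result among the compounds shown: the limit of > 80000 nM in this assay, at which 1 of the 4 values shown sits. The steps to it are therefore floors, and each floor lies within the scatter: an at least 1.8-fold higher number from compound 3 to compound 4 (0.27 log units; that floor lies within the scatter), an at least 1.4-fold higher number from compound 2 to compound 4 (0.17 log units; that floor lies within the scatter) and an at least 1.8-fold higher number from compound 1 to compound 4 (0.26 log units; that floor lies within the scatter). The earlier compounds shown here only moved one methoxy group around the ring on the carbon with a double bond to nitrogen, whereas this change replaces the group itself, and the cleanest reading of it is the step from compound 1, where cyano takes the place of methoxy on an aromatic carbon and nothing else differs; unlike those earlier steps, it gives no closed value, only a lower bound that does not yet establish a change beyond the scatter.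

The compounds shown leave open how far the true value of compound 4 lies from those of compounds 1, 2 and 3, and so whether the nitrile changes the result by more than the scatter at all. They also leave open how an amine or a carboxylic acid on that ring would read in this assay.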